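The compounds below may be only part of what the source reports. "The series", "measured", "known", "first", "only" and "open" are said of these compounds alone.

Measured compounds in an assay on brain for displacement of a labelled ligand from D(3) dopamine receptor (Rattus norvegicus); on this read-out lower numbers stand for stronger inhibition and higher numbers for weaker inhibition:
compound 1 `CCCN(CC[C@H]1CC[C@H](NC(=O)/C=C/c2ccc(F)cc2)CC1)[C@H]1CCc2nc(N)sc2C1` gives 1 nM
compound 2 `CCCN(CC[C@H]1CC[C@H](NS(=O)(=O)c2ccc(OC)cc2)CC1)[C@H]1CCc2nc(N)sc2C1` gives 0.78 nM
compound 3 `CCCN(CC[C@H]1CC[C@H](NS(=O)(=O)c2cccc(Cl)c2)CC1)[C@H]1CCc2nc(N)sc2C1` gives 1.1 nM

Compound 3 gives the highest of the three numbers in this assay, yet its steps to the other two are small: a 1.1-fold higher number from compound 1 to compound 3 (0.04 log units; within the scatter) and a 1.4-fold higher number from compound 2 to compound 3 (0.15 log units; within the scatter). The three compounds therefore sit together, and none of them stands apart beyond the scatter.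

Compound 4 `CCCN(CC[C@H]1CC[C@H](NS(=O)(=O)c2ccc(C(C)(C)C)cc2)CC1)[C@H]1CCc2nc(N)sc2C1` is not yet measured. Against compound 3 it shows (4-(tert-butyl)phenyl in place of 3-chlorophenyl on a sulfonyl sulfur). The measured step that bears on this most directly is the exchange of one aryl group for another on the same sulfonyl sulfur, a 1.4-fold higher number from compound 2 to compound 3 (0.15 log units; within the scatter), which stayed within the scatter. The wider exchanges of the whole group on the amine nitrogen, a 1.3-fold lower number from compound 1 to compound 2 (0.11 log units; within the scatter) and a 1.1-fold higher number from compound 1 to compound 3 (0.04 log units; within the scatter), were likewise within the scatter. Every change so far on this part of the series has left the number in this assay unmoved beyond its scatter, so no step beyond the scatter is expected for compound 4 either. The expected step from compound 3 is a 1.1-fold higher number from compound 3 to compound 4 (0.04 log units; within the scatter). The number estimated for compound 4 in this assay is 1.2 nM, with a range from 0.4 nM to 4 nM.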

Compound 4, inhibition constant: 5 nM
For compound 4 the middle estimate is 4.2-fold (0.62 log units) below the measured one; the whole stated range lies below it.
By their numbers in this assay, from the lowest: compounds 2, 1 and 3 (each within the scatter of the next); then compound 4.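

In this assay, going by these compounds alone, the aryl group on the sulfonyl sulfur now makes a measurable difference: 4-(tert-butyl)phenyl in place of 3-chlorophenyl gives a 4.5-fold higher number from compound 3 to compound 4 (0.66 log units; beyond the scatter), and tert-butyl in place of methoxy on an aromatic carbon gives a 6.4-fold higher number from compound 2 to compound 4 (0.81 log units; beyond the scatter), both modest but the first steps in this set beyond the scatter. This position therefore accepts 3-chlorophenyl and 4-methoxyphenyl without a separable difference, whereas 4-(tert-butyl)phenyl, with 10 heavy atoms against 7 in 3-chlorophenyl, weakens inhibition, although compound 4 still gives 5 nM. Nothing available here accounts for this step.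

The compounds shown leave open whether the higher number is specific to tert-butyl or would also appear with a methyl or isopropyl group in its place on the same phenyl ring, and whether 3-(tert-butyl)phenyl on the sulfonyl sulfur would give a step of similar size. Also open, on these data alone, is how an amine or a carboxylic acid on this phenyl ring would read in this assay.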